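Swapping the Aryl Group on the Acyl Thiosemicarbazide

The source may hold more compounds than are shown below. What is called first, only, known or untested is meant among the compounds shown, and "the series" means these compounds.

Of the compounds shown here, two from a cytotoxicity series have been measured so far. Compound 1 has the structure `COc1cc2ncnc(NNC(=S)NC(=O)c3ccccc3Cl)c2cc1OC` and compound 2 has the structure `COc1ccccc1C(=O)NC(=S)NNc1ncnc2ccccc12`. The read-out is a functional assay on CNE-2 cells (Homo sapiens) for cytotoxicity, read by MTT assay, with a stated time of 72 h; a lower number here means a stronger inhibitor, a higher number a weaker inhibitor. In this assay compound 1 gives 9670 nM, and compound 2 gives 15700 nM. Compound 2 carries the higher of the two numbers, but its gap to compound 1 falls within the scatter of repeated measurements, so the two cannot be ranked against each other on this evidence.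

Compound 3, with the structure `O=C(NC(=S)NNc1ncnc2ccccc12)c1cccc(Cl)c1`, is the next compound to be tested. It differs from compound 2 in one place: 3-chlorophenyl in place of 2-methoxyphenyl on a carbonyl carbon. Among the measured compounds shown here, no measured pair in this set isolates such an exchange, so there is no step to lean on; the two values available show only that changing the aryl group together with the core did not move the number beyond the scatter.

On that basis, the step from compound 2 to compound 3 is expected to be small, a 1.3-fold lower number from compound 2 to compound 3 (0.12 log units; within the scatter), with no clear direction. Compound 3 is estimated to give about 12000 nM in this assay, plausibly between 4000 nM and 40000 nM.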

Compound 3, half-maximal inhibitory concentration: 2920 nM
Beside the measured number, compound 3's estimate is 4.1-fold (0.61 log units) above it, and the stated range ends above it.
By their numbers in this assay, from the lowest: compound 3; then compounds 1 and 2 (each within the scatter of the next).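

With the shared core unchanged, the aryl group on the carbonyl carbon is the only difference between these two compounds, and in this assay 3-chlorophenyl in place of 2-methoxyphenyl gives a 5.4-fold lower number from compound 2 to compound 3 (0.73 log units; beyond the scatter). Among the compounds shown here, this is the first comparison in the set that isolates a single place, and it shows that the number responds to the aryl group at this position, which the earlier pair could not show because its members differ in more than one place. Nothing available explains why this exchange lowers the number.

The exchange replaces methoxy with chlorine and also moves the group from the 2-position to the 3-position of the phenyl ring, so these compounds cannot show whether the identity of the group, its place on the ring, or both lie behind the step. A 3-methoxyphenyl group at the same carbonyl carbon would help to separate those two changes, while an unsubstituted phenyl or a 3-aminophenyl group would show how the number responds to other groups at this position.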